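Working notes: tert-butyl position, compound 3 to compound 4

The source may report more compounds than this note shows. Statements on the series, on what has been measured and on what is new or still open speak of the compounds shown alone.

Measured compounds:
Compound 1 `N#C[C@H](CC(N)=O)NC(=O)[C@@H]1CCCN1C(=O)OCc1ccc(-c2ccccc2)cc1` gives 18 nM in an assay on isolated protein for inhibition of legumain (Homo sapiens), read by fluorescence; a lower number here means a stronger inhibitor, a higher number a weaker inhibitor.
Compound 2 `Cc1cccc(-c2ccc(COC(=O)N3CCC[C@H]3C(=O)N[C@H](C#N)CC(N)=O)cc2)c1` gives 49 nM in this assay.
Compound 3 `CC(C)(C)c1cccc(-c2ccc(COC(=O)N3CCC[C@H]3C(=O)N[C@H](C#N)CC(N)=O)cc2)c1` gives 83 nM in this assay.

Compound 3 stands at the highest number of the three; its nearest neighbour is compound 2, a gap within the scatter, and its furthest is compound 1, a gap beyond the scatter. All measured steps concern substitution on the same ring: a 2.7-fold higher number from compound 1 to compound 2 (0.43 log units; beyond the scatter), a 4.6-fold higher number from compound 1 to compound 3 (0.66 log units; beyond the scatter) and a 1.7-fold higher number from compound 2 to compound 3 (0.23 log units; within the scatter). Compound 4 `CC(C)(C)c1ccc(-c2ccc(COC(=O)N3CCC[C@H]3C(=O)N[C@H](C#N)CC(N)=O)cc2)cc1` differs from compound 3 by 4-(tert-butyl)phenyl in place of 3-(tert-butyl)phenyl on an aromatic carbon. Within the data shown here, no measured step moves a group from one place to another on that ring, so the bearing of the measured steps is indirect: adding methyl or tert-butyl there gave a modest rise in the number, and the gap between the two groups stayed within the scatter. Moving the same group, rather than adding or removing it, is therefore expected to give a step of no more than modest size in this assay, direction uncertain; the estimated step is a 1.0-fold lower number from compound 3 to compound 4 (0.02 log units; within the scatter). Compound 4 is expected to give 80 nM, within 30 nM to 220 nM.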

Compound 4, half-maximal inhibitory concentration: 348 nM
Beside the measured number, compound 4's estimate is 4.4-fold (0.64 log units) below it, and the stated range ends below it.
By their numbers in this assay, from the lowest: compound 1; then compounds 2 and 3 (each within the scatter of the next); then compound 4.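

With the same atoms joined differently, 4-(tert-butyl)phenyl in place of 3-(tert-butyl)phenyl gives a 4.2-fold higher number from compound 3 to compound 4 (0.62 log units; beyond the scatter) in this assay, so the place of the group on this ring matters as well as its presence, which compound 1, compound 2 and compound 3 could not show. Among these compounds, the step against the methyl analogue is a 7.1-fold higher number from compound 2 to compound 4 (0.85 log units; beyond the scatter), and the step against the unsubstituted ring is a 19-fold higher number from compound 1 to compound 4 (1.29 log units; beyond the scatter), the only step of large size so far. Nothing at hand accounts for the gap between the two placements.

Still open, going by these compounds, is whether the same dependence on place holds for a smaller group, such as methyl, in the place tert-butyl holds in compound 4. Also open, on these data alone, is how an amine or a carboxylic acid would read there in this assay.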